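Series notes: a third methoxy on the benzyl ring of compound 2

This account rests on a few compounds, and the source may have more. Where it says the series, first, only, none or still open, it means among the compounds named here.

Measured so far in a functional assay on 786-0 cells (Homo sapiens) for inhibition, read by sulforhodamine B assay, with a stated time of 48 h; on this read-out lower numbers stand for stronger inhibition of growth and higher numbers for weaker inhibition of growth:
compound 1, `Nc1cc(N)c2nc(-c3ccccc3)c(NCc3ccc(Cl)c(Cl)c3)nc2c1`: 30200 nM
compound 2, `COc1ccc(CNc2nc3cc(N)cc(N)c3nc2-c2ccccc2)cc1OC`: 34700 nM
compound 3, `CCOC(=O)[C@H](CCC(=O)O)NC(=O)c1ccc(Sc2nc3cc(N)cc(N)c3nc2-c2ccccc2)cc1`: < 100000 nM, which is a limit of the assay and not a number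

Compound 2 holds the higher of the two numbers recorded in this assay; its nearest neighbour is compound 1, and the gap between them is within the scatter, so no order between the two is claimed. For compound 3 the read-out is only (the limit of < 100000 nM in this assay, at which 1 of the 3 values shown sits), and nothing more is drawn from it.

Compound 4, `COc1cc(CNc2nc3cc(N)cc(N)c3nc2-c2ccccc2)cc(OC)c1OC`, has not yet been measured. It differs from compound 2 by methoxy in place of hydrogen on an aromatic carbon. Going by the values given here, the only measured step that touches this part of the molecule is the exchange of the benzyl substituents, a 1.1-fold higher number from compound 1 to compound 2 (0.06 log units; within the scatter). That step, a change of both substituents on the same ring, stayed within the scatter, so a single further methoxy is expected to shift this assay little, in no clear direction; whether the added oxygen-bearing group pushes the number toward the limit cannot be judged from two numbers.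

Compound 4 is therefore estimated at 36000 nM, with an expected range from 15000 nM to 85000 nM. The step implied by this estimate, a 1.0-fold higher number from compound 2 to compound 4 (0.02 log units; within the scatter), is expected to lie within the scatter.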

Compound 4, concentration for total growth inhibition: < 50200 nM
Compound 4: a limit, no number (the forecaster's own chance of this, stated with the estimate: 15%); the middle value does not contradict the limit.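

Compound 4 gives < 50200 nM in this assay, which is a limit of the assay and not a number, so the step from compound 2 to compound 4 cannot be read. The compounds shown leave open whether methoxy in place of hydrogen on this aromatic carbon shifts growth inhibition at all, and in which direction.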